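The source may hold more compounds than are shown below. What is called first, only, known or untested is meant among the compounds shown, and "the series" means these compounds.

Measured so far in an assay on isolated protein for inhibition of thiosulfate sulfurtransferase (Homo sapiens), with a stated time of 60 min, in the absence of a further agent; a higher number here means a weaker inhibitor, a lower number a stronger inhibitor. Compound 1 `COc1c(Br)cccc1C(=O)Nc1ccc(Sc2nc3ccccc3s2)cc1` gives > 100000 nM, which is a limit of the assay. Compound 2 `O=C(Nc1ccc(Sc2nc3ccccc3s2)c(Cl)c1)c1cccc(Br)c1` gives > 100000 nM, also a limit. Compound 3 `O=C(Nc1ccc(Sc2nc3ccccc3s2)cc1)c1cc(Br)cc(Br)c1O` gives > 100000 nM, again a limit.

Going by the values given here, compound 3 therefore stands at the same point as the other two; all three values shown sit at the limit of > 100000 nM in this assay, at which 3 of the 3 values shown sit, and no compound can be ranked against another. The one single-point step shown, a step that the two limits leave unreadable from compound 1 to compound 3, runs from one limit to another and its size cannot be read.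

Compound 4 `O=C(Nc1ccc(Sc2nc3ccccc3s2)cc1)c1cccc(Br)c1` differs from compound 3 by 3-bromophenyl in place of 3,5-dibromo-2-hydroxyphenyl on a carbonyl carbon. Among the compounds with values here, no measured step bears directly on this change, and the step that exists gives no size. The step of a number no higher from compound 3 to compound 4 (the limit leaves the size open) is expected to be nothing readable beyond the scatter. Compound 4 in this assay is estimated at 100000 nM, range 20000 nM to 300000 nM, most likely reported again as a limit.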

Compound 4, half-maximal inhibitory concentration: > 100000 nM
Compound 4 was reported as a limit (the forecaster's own chance of this, stated with the estimate: 80%); the middle value lies on the limit itself.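

Compound 4 is also a limit, so the steps to it from compound 1, compound 2 and compound 3 cannot be read: the limit of > 100000 nM in this assay, at which 4 of the 4 values shown sit. The compounds shown leave open which change to the shared core, if any, would give a measurable value in this assay.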